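Ethoxy Added to the Phenyl of Compound 3

The compounds below may be only part of what the source reports. "The series", "measured", "known", "first", "only" and "open" are said of these compounds alone.

Compound 3 `C=C(Br)C(=O)Nc1cccc(-c2cn3nc(-c4ccccc4)sc3n2)c1` gives 1400 nM in a functional assay on HeLa cells (Homo sapiens) for inhibition, read by cell counting, with a stated time of 4 days (a lower number here means a stronger inhibitor, a higher number a weaker inhibitor), the lowest of the three numbers shown, though its gap to compound 1 `C=C(Br)C(=O)Nc1cccc(-c2cn3nc(Cc4cccc(OC)c4)sc3n2)c1`, which gives 2500 nM, stays within the scatter; compound 2 `C=C(Br)C(=O)Nc1cccc(-c2cn3nc(Cc4ccccc4)sc3n2)c1` gives 4500 nM. The step of a 3.2-fold lower number from compound 2 to compound 3 (0.51 log units; beyond the scatter) is the only one beyond the scatter, while a 1.8-fold lower number from compound 1 to compound 3 (0.25 log units; within the scatter) is not. Compound 4 `C=C(Br)C(=O)Nc1cccc(-c2cn3nc(-c4ccc(OCC)cc4)sc3n2)c1` differs from compound 3 by ethoxy in place of hydrogen on an aromatic carbon. For the measured compounds named here, the one measured step that touches an alkoxy group is a 1.8-fold higher number from compound 1 to compound 2 (0.26 log units; within the scatter), and it stays within the scatter. Going by the values given here, no measured pair shows an ether placed on a phenyl attached directly to the core, so only a small change is expected. Compound 4 is therefore estimated at 1000 nM, within 400 nM to 3000 nM. The expected step is a 1.4-fold lower number from compound 3 to compound 4 (0.15 log units; within the scatter).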

Compound 4, half-maximal inhibitory concentration: 1100 nM
Compound 4: middle estimate off by 1.1-fold (0.04 log units), on the low side; the measured number falls inside the stated range.
By their numbers in this assay, from the lowest: compounds 4, 3, 1 and 2 (each within the scatter of the next, the first and the last beyond it).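

Ethoxy on the phenyl, para to a large group, leaves the number in this assay within the scatter of the unsubstituted phenyl (a 1.3-fold lower number from compound 3 to compound 4 (0.10 log units; within the scatter)). The step from the benzyl series remains beyond the scatter (a 4.1-fold lower number from compound 2 to compound 4 (0.61 log units; beyond the scatter)). Against the 3-methoxybenzyl compound, the 4-ethoxyphenyl group gives a step beyond the scatter (a 2.3-fold lower number from compound 1 to compound 4 (0.36 log units; beyond the scatter)), which the plain phenyl of compound 3 did not give.

As far as these compounds go, whether an amine, a carboxylic acid or a longer chain at this place would behave like ethoxy remains open. Nothing given here explains these steps.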